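The compounds below may be only part of what the source reports. "The series", "measured", "known", "first", "only" and "open" are said of these compounds alone.

In a physicochemical assay for solubility, at pH 2 (a higher number here means a more soluble compound, a lower number a less soluble compound), compound 1 `CC(C)Nc1nc(NCc2ccco2)c2cccc(Cl)c2n1` gives >= 30000 nM, which is a limit of the assay and not a number. Compound 2 `CC(C)Nc1nc(NCc2ccco2)c2cc(Cl)ccc2n1` gives >= 30000 nM, again a limit. Compound 3 `Cc1cccc2c(NCc3ccco3)nc(NC(C)C)nc12` gives >= 30000 nM, also a limit.

Compound 1 and compound 2 are built from the same atoms joined differently; the difference between the two cores is not broken down here. Compound 3 arises from compound 1 by methyl in place of chloro on an aromatic carbon. The size of the step that the two limits leave unreadable from compound 1 to compound 3 cannot be read, because of the limit of >= 30000 nM in this assay, at which 3 of the 3 values shown sit.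

Compound 4 `Cc1ccc2nc(NC(C)C)nc(NCc3ccco3)c2c1` has not yet been measured. It arises from compound 2 by the same kind of change, (methyl in place of chloro on an aromatic carbon), but at a different place: in the first pair the carbon is ortho to a fused ring and meta to a fused ring, in the second it is meta to a fused ring and para to a fused ring.

In this assay compound 4 is expected at 60000 nM, between 30000 nM and 200000 nM. The step that the limit leaves unreadable from compound 2 to compound 4 is expected to be small, an expectation that rests on (the limit of >= 30000 nM in this assay, at which 3 of the 3 values shown sit), where every measured value here sits.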

Compound 4, solubility: >= 30000 nM
Compound 4: a limit, no number; the forecaster's own chance of this, stated with the estimate: 85%; the middle value does not contradict the limit.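

No size can be read for the step from compound 2 to compound 4, because both values in this assay are limits of the assay and not numbers: the limit of >= 30000 nM in this assay, at which 4 of the 4 values shown sit.

The compounds shown leave open how soluble each of the four really is, and whether methyl in place of chloro changes that at either place.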